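The source may hold more compounds than are shown below. What is called first, only, known or untested is meant among the compounds shown, and "the series" means these compounds.

Compound 2 `COc1ccc(/N=C/c2ccccc2O)cc1` gives 11.5% in an assay on isolated protein for inhibition of lysosomal alpha-glucosidase (Rattus norvegicus), with stated times of 5 min and 10 min, tested at 200 uM; a lower number here means less inhibition, a higher number more inhibition at the concentration tested (going by the name of the read-out). Compound 1 `Oc1ccccc1/C=N/c1ccc(Cl)cc1` gives 5.63% in this assay, and the two numbers lie within the scatter of each other, so neither stands apart. Going by the values given here, the only measured step, a number 5.9 percentage points higher from compound 1 to compound 2 (within the scatter), changes little. Compound 3 `O=[N+]([O-])c1ccc(/N=C/c2ccccc2O)cc1` differs from compound 2 by nitro in place of methoxy on an aromatic carbon. Among the compounds with values here, no measured step exchanges these two groups, so the evidence is just the pair of low values seen so far, and no step beyond the scatter is expected. Compound 3 is therefore expected at 10%, most likely between 2% and 22%. That expectation means a step of a number 1.5 percentage points lower from compound 2 to compound 3 (within the scatter).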

Compound 3, a percentage reported as inhibition, at one concentration (the size of the read-out at that concentration, not a potency): 95.6%
The estimate for compound 3 lay 85.6 percentage points below the measured number; measured number outside the range, above it.
By their numbers in this assay, from the lowest: compounds 1 and 2 (each within the scatter of the next); then compound 3.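

Exchanging methoxy for nitro gives a number 84.1 percentage points higher from compound 2 to compound 3 (beyond the scatter) and exchanging chloro for nitro gives a number 90 percentage points higher from compound 1 to compound 3 (beyond the scatter), so the group on this aromatic carbon can matter far more in this assay than the step between the first two compounds suggested. Of the three groups, only nitro stands apart. Nothing measured here accounts for that difference.

On these data alone, it remains open whether an amine or a carboxylic acid on this carbon would behave like nitro. A single tested concentration also leaves the potency of compound 3 unknown.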